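Free Hydroxyl in Place of a Silyl Ether

This account rests on a few compounds, and the source may have more. Where it says the series, first, only, none or still open, it means among the compounds named here.

Compound 1 `COc1ccc(C2=C(c3cc(OC)c(OC)c(OC)c3)C(=O)C(O[SiH2]C(C)(C)C)C2)cc1OC(C)C`: 7 ug/mL
Compound 2 `COc1ccc(C2=C(c3cc(OC)c(OC)c(OC)c3)C(=O)CC2OC(C)=O)cc1NC=O`: 2 ug/mL
Compound 3 `COc1ccc(C2=C(c3cc(OC)c(OC)c(OC)c3)C(=O)C(O[SiH2]C(C)(C)C)C2)cc1`: 9 ug/mL

In an ADME assay on L132 cells (Homo sapiens) for cytotoxicity, read by MTT assay, with a stated time of 72 h (a higher number here means a weaker inhibitor, a lower number a stronger inhibitor), compound 1 gives 7 ug/mL, the second highest of the three numbers. Within the data shown here, the single measured step, a 1.3-fold higher number from compound 1 to compound 3 (0.11 log units; within the scatter), lies within the scatter. Among the measured compounds shown here, compound 2 gives 2 ug/mL, the furthest value from compound 1, but it differs from compound 1 in two places, so no step is drawn between them.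

Compound 4 `COc1ccc(C2=C(c3cc(OC)c(OC)c(OC)c3)C(=O)C(O)C2)cc1OC(C)C` differs from compound 1 by a hydrogen atom in place of a group of 5 heavy atoms (4 carbon, 1 silicon; no ring), on an oxygen on a saturated carbon. For the measured compounds named here, no measured step touches this oxygen; the one step available concerns an aromatic carbon and is small. With nothing comparable to lean on, the expected step from compound 1 to compound 4 is a 1.4-fold lower number from compound 1 to compound 4 (0.15 log units; within the scatter), a modest lowering not clearly beyond the scatter. Compound 4 is therefore estimated at 5 ug/mL, with a range of 2 ug/mL to 15 ug/mL.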

Compound 4, half-maximal inhibitory concentration: > 100 ug/mL
Compound 4: no number, only a limit; the forecaster's own chance of this, stated with the estimate: 5%; at least 20-fold (1.30 log units) between middle value and limit.
By their numbers in this assay, from the lowest: compound 2; then compounds 1 and 3 (each within the scatter of the next). At a limit, above all of these: compound 4.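

In this assay, compound 4 gives > 100 ug/mL, which is a limit of the assay and not a number. Among these compounds, putting a hydrogen atom in place of the group of 5 heavy atoms on this oxygen gives an at least 14-fold higher number from compound 1 to compound 4 (1.15 log units; beyond the scatter), so this oxygen is a place where a change registers clearly, unlike the one earlier step, which stayed within the scatter. The true size of the step remains unknown, as it ends at a limit: the limit of > 100 ug/mL in this assay, at which 1 of the 4 values shown sits.

From the compounds shown here alone, whether a methyl ether or a benzyl ether on this oxygen would read like compound 1 or like compound 4 remains open.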